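The source may hold more compounds than are shown below. What is called first, only, known or untested is meant among the compounds shown, and "the series" means these compounds.

Among the measured compounds shown here, in an ADME assay on CHO cells (Cricetulus griseus) for cytotoxicity, read by MTT assay (a higher number here means that more compound is tolerated, a lower number that less compound is tolerated), only two numbers exist so far: compound 1 (`Fc1ccc(-c2nc3c(N4CCNCC4)nccc3[nH]2)cc1F`) gives 8100 nM and compound 2 (`C[C@@H]1CN(c2nccc3[nH]c(-c4ccc(F)c(F)c4)nc23)C[C@H](C)N1`) gives 6500 nM on the same core. These two values lie within the scatter of each other, so compound 2 cannot be told apart from compound 1 on these numbers.

Compound 3 (`Fc1ccc(-c2nc3c(N4CCCNCC4)nccc3[nH]2)cc1F`) has not yet been measured. It carries 1,4-diazepan-1-yl in place of 3,5-dimethylpiperazin-1-yl on an aromatic carbon. For the measured compounds named here, one measured step bears on this change, since it involves the same aromatic carbon: the step of a 1.2-fold lower number from compound 1 to compound 2 (0.10 log units; within the scatter) came with 3,5-dimethylpiperazin-1-yl in place of piperazin-1-yl and stayed within the scatter. Going by the values given here, no compound with a seven-membered ring at this place has been measured, so the guidance is indirect and the range must stay wide. No shift beyond the scatter is expected, in either direction. The estimated step is a 1.1-fold higher number from compound 2 to compound 3 (0.03 log units; within the scatter) and it remains within that expectation. For compound 3 the expected value is 7000 nM in this assay (estimated range 3000 nM to 16000 nM).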

Compound 3, half-maximal cytotoxic concentration: 7200 nM
Compound 3: the middle estimate sits 1.0-fold (0.01 log units) below what was measured; low and high end bracket the measured number.
By their numbers in this assay, from the lowest: compounds 2, 3 and 1 (each within the scatter of the next).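

Placing 1,4-diazepan-1-yl on this aromatic carbon, next to the ring nitrogen, gives a 1.1-fold higher number from compound 2 to compound 3 (0.04 log units; within the scatter) in this assay, and compared with piperazin-1-yl it gives a 1.1-fold lower number from compound 1 to compound 3 (0.05 log units; within the scatter) on the same scale. A seven-membered ring therefore joins the two six-membered rings at this place, and the three compounds cannot be told apart on these numbers, whether the ring is enlarged or carries two methyl groups. This flat picture holds only for these three cyclic diamines on the shared core, and nothing at hand accounts for it.

The compounds shown leave open whether this tolerance of change extends to groups of another kind at the same carbon, such as morpholin-4-yl, an open-chain amine like dimethylamino, or a carboxylic acid. They also leave open whether a larger substituent on the diazepane ring, such as a benzyl group on its free nitrogen, would move the number beyond the scatter.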